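Benzyl in place of the dioxolane on a triazole series

The compounds below may be only part of what the source reports. "The series", "measured", "known", "first", "only" and "open" are said of these compounds alone.

Measured so far:
compound 1, `CCOC(=O)Cn1cc(-c2ccc(OC)c(OC)c2OC)nn1` — > 100000 nM
compound 2, `CC1(C)OCC(Cn2cc(-c3ccc(C(F)(F)F)cc3)nn2)O1` — 13500 nM
compound 3, `OCCCn1cc(-c2ccc3ccccc3c2)nn1` — > 100000 nM

Compound 2 is the only one of the three that gives a number in a functional assay on B16 cells (Mus musculus) for cytotoxicity, read by MTT assay, with a stated time of 48 h; a higher number here means a weaker inhibitor, a lower number a stronger inhibitor. Compound 1 reaches only a limit, > 100000 nM, and no number. Compound 3 likewise sits at a limit, > 100000 nM. So compound 2 stands alone with a measured value, while two of the three values are limits, as seen in the limit of > 100000 nM in this assay, at which 2 of the 3 values shown sit.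

Compound 4, `FC(F)(F)c1ccc(-c2cn(Cc3ccccc3)nn2)cc1`, has not been measured in this assay. It differs from compound 2 in one place: phenyl in place of 2,2-dimethyl-1,3-dioxolan-4-yl on a saturated chain carbon bound to an aromatic nitrogen. No measured pair with a single change is available, so the size and direction of the step cannot be read from the data shown. A modest step, within or just beyond the scatter, is expected from compound 2 to compound 4, a 1.7-fold lower number from compound 2 to compound 4 (0.23 log units; within the scatter). Compound 4 is therefore expected to give about 8000 nM in this assay, within the range 2000 nM to 40000 nM.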

Compound 4, half-maximal inhibitory concentration: > 100000 nM
Compound 4 ended at the assay's limit; the forecaster's own chance of this, stated with the estimate: 20%; middle value at least 12-fold (1.09 log units) away from the limit.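

In this assay, among the compounds shown here, this is the first change in one place that can be read: phenyl in place of 2,2-dimethyl-1,3-dioxolan-4-yl on a saturated chain carbon bound to an aromatic nitrogen gives an at least 7.4-fold higher number from compound 2 to compound 4 (0.86 log units; beyond the scatter). For the compounds shown here, compound 1 and compound 3 differ from these two compounds in more than one place and give no readable step, so only this pair shows that the group at this position alone can separate a measured value from none. The value of compound 4 is a limit and not a number, so the step gives only a minimum size: the limit of > 100000 nM in this assay, at which 3 of the 4 values shown sit.

The compounds shown do not tell whether the dioxolane ring itself is needed for a measured value. As far as these compounds go, an open-chain diol, a morpholine or a cyclohexyl at this place remains untested here.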